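Swapping Phenyl for Methyl: One Change, Two Chains

This account rests on a few compounds, and the source may have more. Where it says the series, first, only, none or still open, it means among the compounds named here.

Of the compounds shown here, three have been measured in a functional assay on the whole organism with Rattus norvegicus as the target, at a dose of 100 mg/kg; on this read-out higher numbers stand for more inhibition at the one dose given (going by the name of the read-out) and lower numbers for less inhibition. Compound 1 `CC/N=C(/NC#N)NCCCCn1nc(-c2ccccc2)ccc1=O` carries a phenyl group on its ring and a four-carbon chain; in this assay compound 1 gives 58.8%. Compound 2 `CC/N=C(/NC#N)NCCCn1nc(-c2ccccc2)ccc1=O` has the same phenyl group on a three-carbon chain, and in this assay compound 2 gives 62.9%; the difference between the two cores is not broken down here, and the two values lie within the scatter of each other. Compound 3 `CC/N=C(/NC#N)NCCCn1nc(C)ccc1=O` keeps the three-carbon chain of compound 2 but bears a methyl group where compound 2 has phenyl, and in this assay compound 3 gives 34.5%.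

The change from compound 2 to compound 3 is methyl in place of phenyl on an aromatic carbon, and it produced a number 28.4 percentage points lower from compound 2 to compound 3 (beyond the scatter). The same change, (methyl in place of phenyl on an aromatic carbon), turns compound 1 into the unmeasured compound 4 `CC/N=C(/NC#N)NCCCCn1nc(C)ccc1=O`, a methyl analogue with the four-carbon chain. The two surroundings of the change are described in identical words, so this is the same change made on a different core.

Because compound 2 to compound 3 gave a number 28.4 percentage points lower from compound 2 to compound 3 (beyond the scatter), a step of similar size is expected for compound 4, namely a number 27.8 percentage points lower from compound 1 to compound 4 (beyond the scatter). Compound 4 is therefore estimated to reach about 31% in this assay, most likely between 17% and 45%. This expectation rests on a single matched pair, so it carries real uncertainty.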

Compound 4, a percentage reported as inhibition, in the whole organism at one dose (the size of the read-out at that dose, not a potency): 13.5%
Compound 4: middle estimate off by 17.5 percentage points, on the high side, and the stated range ends above it.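

In this assay, the same swap on the core of compound 1 gave a number 45.3 percentage points lower from compound 1 to compound 4 (beyond the scatter). The direction carried over from one core to the other, since methyl in place of phenyl lowered the number both times, but the size of the step did not carry over: the same change on two cores in this assay, a number 28.4 percentage points lower (beyond the scatter) from compound 2 to compound 3 and a number 45.3 percentage points lower (beyond the scatter) from compound 1 to compound 4, 16.9 percentage points apart, beyond the scatter of two such steps So a step measured on one core was a fair guide to the direction on the other core in this pair, but a poor guide to how far the number would fall, and these two pairs alone show neither why the steps differ nor whether the same gap would appear on any further core in this series.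

On these data alone, what remains open is how the number behaves with other groups on the same aromatic carbon, such as ethyl, cyclohexyl or a substituted phenyl, which could show whether the loss on leaving phenyl builds up gradually or appears all at once. As far as these compounds go, it is also open whether a longer chain would widen the gap between the phenyl and methyl compounds further, and whether the results at this one dose would hold at other doses.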